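Adding a Chloro Group to the Pyridine-Bearing Analogue

The source may hold more compounds than are shown below. What is called first, only, known or untested is meant among the compounds shown, and "the series" means these compounds.

Measured compounds:
Compound 1 `Cc1ncc([N+](=O)[O-])n1CCSc1nnc(-c2ccccc2)o1`: 20500 nM
Compound 2 `Cc1ncc([N+](=O)[O-])n1CCSc1nnc(-c2ccccc2Cl)o1`: 22500 nM
Compound 3 `Cc1ncc([N+](=O)[O-])n1CCSc1nnc(-c2ccncc2)o1`: 12600 nM

All three were tested in a functional assay on MCF7 cells (Homo sapiens) for cytotoxicity, read by MTT assay, with a stated time of 48 h; on this read-out lower numbers stand for stronger inhibition and higher numbers for weaker inhibition. Compound 1 and compound 2 differ by chloro in place of hydrogen on an aromatic carbon. That step gave a 1.1-fold higher number from compound 1 to compound 2 (0.04 log units; within the scatter). Compound 1 and compound 3 differ in their cores by pyridin-4-yl in place of phenyl on an aromatic carbon, a change that gave a 1.6-fold lower number from compound 1 to compound 3 (0.21 log units; within the scatter), while the step of a 1.8-fold lower number from compound 2 to compound 3 (0.25 log units; within the scatter) is likewise small. None of these three steps reaches beyond the scatter, so the three values are best read as alike.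

Compound 4 `Cc1ncc([N+](=O)[O-])n1CCSc1nnc(-c2ccnc(Cl)c2)o1` has not yet been measured. It differs from compound 3 by chloro in place of hydrogen on an aromatic carbon. Among the compounds with values here, this is the same kind of change as the one from compound 1 to compound 2, but not the same: in compound 1 the chloro enters on an aromatic carbon of a six-membered aromatic ring of carbon only, ortho to a large group, whereas in compound 3 it enters on an aromatic carbon of a six-membered aromatic ring with 1 nitrogen, next to the ring nitrogen and meta to a large group.

Beside the earlier chloro step, a 1.1-fold higher number from compound 1 to compound 2 (0.04 log units; within the scatter), the step from compound 3 to compound 4 in this assay is expected to be a 1.1-fold higher number from compound 3 to compound 4 (0.05 log units; within the scatter). Within the data shown here, this expectation rests on the earlier chloro step, which gave a 1.1-fold higher number from compound 1 to compound 2 (0.04 log units; within the scatter) and stayed within the scatter, with only one such example to draw on. Compound 4 is therefore estimated at 14000 nM, with a likely range from 7000 nM to 28000 nM.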

Compound 4, half-maximal inhibitory concentration: 40500 nM
For compound 4 the middle estimate is 2.9-fold (0.46 log units) below the measured one; measured number above the stated range.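

In this assay, chloro in place of hydrogen gives a 3.2-fold higher number from compound 3 to compound 4 (0.51 log units; beyond the scatter), so on the core of compound 3 this small change has a measurable effect, though only a modest one. Within the data shown here, the size of the step does not carry over from one core to the other: the same change on two cores in this assay, a 1.1-fold higher number (0.04 log units; within the scatter) from compound 1 to compound 2 and a 3.2-fold higher number (0.51 log units; beyond the scatter) from compound 3 to compound 4, 2.9-fold (0.47 log units) apart, beyond the scatter of two such steps The comparison rests on only one pair for each core, so it shows that the chloro step depends on its setting in these four compounds, but it gives no reason for the difference and no rule for other cores; compound 4 also stands apart only from compound 3, since a 1.8-fold higher number from compound 2 to compound 4 (0.26 log units; within the scatter) and a 2.0-fold higher number from compound 1 to compound 4 (0.30 log units; within the scatter) both stay within the scatter.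

The compounds shown leave open whether this step belongs to chloro specifically or would also appear with fluoro, methoxy or an amine in the same place on the pyridin-4-yl group. Among these compounds, they also leave open whether a second chloro-bearing pair on a further core would resemble the step from compound 1 to compound 2 or the one from compound 3 to compound 4.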